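Swapping a Six-Membered Ring for Thiophene

A few compounds are considered here, and "the series" means these few. Any claim that something is new, unique, unknown or untested is made for them only; others in the source may bear on it.

In a functional assay on PC-3 cells (Homo sapiens) for antiproliferative activity, read by CCK-8 assay, with a stated time of 6 days (a higher number here means a weaker inhibitor, a lower number a stronger inhibitor), compound 1 `CCN(c1ccc(C#N)c(Cl)c1)c1cc(-c2ccncc2)ccc1C` gives 3580 nM. Compound 2 `CCN(c1ccc(C#N)c(Cl)c1)c1cc(-c2cncnc2)ccc1C` differs from it only where pyrimidin-5-yl stands in place of pyridin-4-yl, and in this assay compound 2 reaches only the limit of > 30000 nM, so its true value is not known as a number. That change gives an at least 8.3-fold higher number from compound 1 to compound 2 (0.92 log units; beyond the scatter), and since the limit of > 30000 nM in this assay, at which 1 of the 2 values shown sits, sets the ceiling, the real loss may be larger. Compound 3 `CCN(c1ccc(C#N)c(Cl)c1)c1cc(-c2cccs2)ccc1C` carries the change (thiophen-2-yl in place of pyrimidin-5-yl on an aromatic carbon). For the measured compounds named here, no measured pair involves thiophen-2-yl, so the only guide is that the ring at this position can move the number by at least the size of an at least 8.3-fold higher number from compound 1 to compound 2 (0.92 log units; beyond the scatter). Compound 3 is therefore expected to land somewhere between compound 1 and the limit, with a step of an at least 5.0-fold lower number from compound 2 to compound 3 (0.69 log units; beyond the scatter) expected from compound 2. The estimate for compound 3 is 6000 nM, with a range from 1500 nM to 30000 nM.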

Compound 3, half-maximal inhibitory concentration: > 30000 nM
Compound 3: a limit, no number; the forecaster's own chance of this, stated with the estimate: 25%; middle value at least 5.0-fold (0.69 log units) from the limit.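

Thiophen-2-yl in place of pyridin-4-yl gives an at least 8.3-fold higher number from compound 1 to compound 3 (0.92 log units; beyond the scatter), so a second ring, this time five-membered and carrying sulfur, also falls short of compound 1. Of the three rings shown at this carbon, only pyridin-4-yl gives a real number in this assay, with compound 1 at 3580 nM. The step from compound 2 to compound 3 cannot be read, and the two cannot be ranked, because both stop at the same ceiling: the limit of > 30000 nM in this assay, at which 2 of the 3 values shown sit.

The compounds shown leave open whether a plain phenyl ring, a pyridin-3-yl ring or an amine such as morpholine at this carbon would match compound 1 or improve on it. As far as these compounds go, how far compound 2 and compound 3 truly lie beyond the limit also remains unknown.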